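This account rests on a few compounds, and the source may have more. Where it says the series, first, only, none or still open, it means among the compounds named here.

In a functional assay on V79 cells (Cricetulus griseus) for cytotoxicity, read by colony formation (a higher number here means a weaker inhibitor, a lower number a stronger inhibitor), the measured compounds are:
- compound 1 `O=C(O)c1cn(C2CC2)c2cc(N3CCCC3)c(F)cc2c1=O`: 38 ug/mL
- compound 2 `O=C(O)c1cn(C2CC2)c2c(Cl)c(N3CCCC3)c(F)cc2c1=O`: 150 ug/mL
- compound 3 `COc1c(N2CCCC2)c(F)cc2c(=O)c(C(=O)O)cn(C3CC3)c12`: 150 ug/mL

Compound 1 has the lowest number of the three in this assay. Compound 4 `CC1CN(c2cc3c(cc2F)c(=O)c(C(=O)O)cn3C2CC2)CC(C)N1` keeps the core of compound 1 but carries a different group: 3,5-dimethylpiperazin-1-yl in place of pyrrolidin-1-yl on an aromatic carbon. For the measured compounds named here, no measured step changes the pyrrolidin-1-yl group, so the evidence is only indirect. Chloro in place of hydrogen gives a 3.9-fold higher number from compound 1 to compound 2 (0.60 log units; beyond the scatter), and methoxy in place of hydrogen gives a 3.9-fold higher number from compound 1 to compound 3 (0.60 log units; beyond the scatter). Between the two substituted compounds there is no change at the digits printed from compound 2 to compound 3 (within the scatter). These steps, made elsewhere on the core, show only how far a single change has moved the number in this small set. Their direction cannot be carried over with confidence, but both start from compound 1 and rise. A modest step towards a higher number is therefore expected, with wide uncertainty. The estimated change is a 2.1-fold higher number from compound 1 to compound 4 (0.32 log units; beyond the scatter). The expected value for compound 4 is 80 ug/mL, within an estimated range of 25 ug/mL to 250 ug/mL.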

Compound 4, half-maximal inhibitory concentration: > 500 ug/mL
Compound 4: no number, only a limit; the forecaster's own chance of this, stated with the estimate: 10%; middle value at least 6.2-fold (0.79 log units) away from the limit.
By their numbers in this assay, from the lowest: compound 1; then compounds 2 and 3 (each within the scatter of the next). At a limit, above all of these: compound 4.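

In this assay, 3,5-dimethylpiperazin-1-yl in place of pyrrolidin-1-yl on the aromatic carbon ortho to a fluoro group gives an at least 13-fold higher number from compound 1 to compound 4 (1.11 log units; beyond the scatter). This is the only step shown at this position, and it is large, whereas the chloro and methoxy steps made elsewhere on the core were modest, so the group on this carbon can move the number further than those changes did here. The reading for compound 4 is a limit, not a number: the limit of > 500 ug/mL in this assay, at which 1 of the 4 values shown sits.

The change alters the ring size, the ring nitrogen count and the two methyl groups all at once, and the compounds shown do not separate these. Piperazin-1-yl without the methyl groups, or piperidin-1-yl, would be needed to tell which part goes with the step.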